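Chloro on the Triazole-Bound Phenyl of an Inert Ester

This account rests on a few compounds, and the source may have more. Where it says the series, first, only, none or still open, it means among the compounds named here.

Compound 2, with the structure `C/C(=C\CC/C(C)=C/CC[C@@H]1[C@@]2(C)CCC(=O)C(C)(C)[C@H]2CC[C@@]1(C)O)CC/C=C(\C)C(=O)OCc1cn(-c2ccccc2)nn1`, is the starting point. In an ADME assay on L132 cells (Homo sapiens) for cytotoxicity, read by MTT assay, with a stated time of 48 h (on this read-out higher numbers stand for weaker inhibition and lower numbers for stronger inhibition), compound 2 gives > 150000 nM, which is a limit of the assay and not a number. Two measured companions share its core. Compound 1, `C/C(=C\CC/C(C)=C/CC[C@@H]1[C@@]2(C)CCC(=O)C(C)(C)[C@H]2CC[C@@]1(C)O)CC/C=C(\C)C(=O)OCc1cn(-c2ccc(C(F)(F)F)cc2)nn1`, carries a trifluoromethyl on the phenyl; in this assay compound 1 gives > 150000 nM, again a limit. Compound 3, `C/C(=C\CC/C(C)=C/CC[C@@H]1[C@@]2(C)CCC(=O)C(C)(C)[C@H]2CC[C@@]1(C)O)CC/C=C(\C)C(=O)OCc1cn(-c2ccccc2[N+](=O)[O-])nn1`, carries a nitro on the phenyl; in this assay compound 3 gives > 150000 nM, also a limit. All three values therefore sit at the limit of > 150000 nM in this assay, at which 3 of the 3 values shown sit, and every comparison between them is unreadable: a step that the two limits leave unreadable from compound 1 to compound 2, a step that the two limits leave unreadable from compound 2 to compound 3 and a step that the two limits leave unreadable from compound 1 to compound 3.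

The unmeasured compound 4 has the structure `C/C(=C\CC/C(C)=C/CC[C@@H]1[C@@]2(C)CCC(=O)C(C)(C)[C@H]2CC[C@@]1(C)O)CC/C=C(\C)C(=O)OCc1cn(-c2ccc(Cl)cc2)nn1`. Compared with compound 2 the change is chloro in place of hydrogen on an aromatic carbon. Among the compounds with values here, no measured step gives a readable size for this kind of change, since each step between the three measured compounds is hidden by the limit. Within the data shown here, the only guidance is that varied phenyl substituents have left every value at the limit. Compound 4 is therefore expected to show a step that the limit leaves unreadable from compound 2 to compound 4, no step beyond the scatter. Compound 4 is estimated at 200000 nM, in a range from 80000 nM to 600000 nM.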

Compound 4, half-maximal inhibitory concentration: > 150000 nM
Compound 4 ended at the assay's limit (the forecaster's own chance of this, stated with the estimate: 85%); the middle value lies beyond the limit too.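

In this assay compound 4 gives > 150000 nM, which is a limit of the assay and not a number. Within the data shown here, no step between compound 4 and compound 1, compound 2 or compound 3 can be read, because all four compounds end at the same limit: the limit of > 150000 nM in this assay, at which 4 of the 4 values shown sit.

The compounds shown leave open how far these four differ from one another, and whether any other phenyl substituent would give a value inside the assay's range.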